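A few compounds are considered here, and "the series" means these few. Any claim that something is new, unique, unknown or untested is made for them only; others in the source may bear on it.

Compound 2 `CN1CCN(C(=S)SCc2ccc(C(=O)Nc3ccccc3N)cc2)CC1` is the higher of the two compounds measured in a functional assay on A-375 cells (Homo sapiens) for antiproliferative activity, read by CCK-8 assay, with a stated time of 72 h, tested at 8 uM (a higher number here means a stronger effect of the compound at the concentration tested, a lower number a weaker effect), where compound 2 gives 91.6%. Its nearest neighbour is compound 1 `Nc1ccccc1NC(=O)c1ccc(CSC(=S)N2CCc3ccccc32)cc1`, which in this assay gives 85.4%; the change from compound 1 to compound 2 was a number 6.2 percentage points higher from compound 1 to compound 2 (within the scatter), a gap that the scatter of such measurements covers.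

The next compound, compound 3 `CN(Cc1cccnc1)C(=S)SCc1ccc(C(=O)Nc2ccccc2N)cc1`, differs from compound 2 at the same position as that earlier step: methyl((pyridin-3-yl)methyl)amino in place of 4-methylpiperazin-1-yl on a thiocarbonyl carbon. For the measured compounds named here, the only measured step that bears on this place is the one at the thiocarbonyl carbon already described, and since it was a number 6.2 percentage points higher from compound 1 to compound 2 (within the scatter), the data give no sign that the group on the thiocarbonyl carbon shifts the read-out of this assay beyond its scatter. Compound 3 is therefore expected to give a result close to that of compound 2, with a step of a number 4.6 percentage points lower from compound 2 to compound 3 (within the scatter) expected in this assay. The estimate for compound 3 in this assay is 87%, with a range from 72% to 96%.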

Compound 3, a percentage reported as inhibition, at one concentration (the size of the read-out at that concentration, not a potency): 83.8%
For compound 3 the middle estimate is 3.2 percentage points above the measured one, within the range that was stated.
By their numbers in this assay, from the lowest: compounds 3, 1 and 2 (each within the scatter of the next).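

With methyl((pyridin-3-yl)methyl)amino on the thiocarbonyl carbon, this assay gives a number 7.8 percentage points lower from compound 2 to compound 3 (within the scatter) and a number 1.6 percentage points lower from compound 1 to compound 3 (within the scatter), so all three groups tested at this position now lie within the scatter of one another. The earlier pair had the nitrogen on the thiocarbonyl carbon held inside a ring in both compounds, whereas compound 3 carries it in an open form with a methyl and a (pyridin-3-yl)methyl group, and this change of shape in the substituent brings no step beyond the scatter at the one concentration tested. Since the read-out is the size of the effect at that concentration and not a potency, this shows only that the three groups cannot be told apart here, and nothing shown bears on why they read alike.

From the compounds shown here alone, it remains open whether a much smaller group such as dimethylamino, or a group carrying a carboxylic acid, on the thiocarbonyl carbon would also stay within the scatter. Going by these compounds, it also remains open whether compounds 1, 2 and 3 would separate at a lower concentration.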